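Para substituent swap on the anilide, cytotoxicity outlook

The source may hold more compounds than are shown below. What is called first, only, known or untested is meant among the compounds shown, and "the series" means these compounds.

The series shares one core, varied only at the anilide ring. Compound 1 `CCCCc1nc(Cl)c(C2NC(=O)NC(C)=C2C(=O)Nc2cccc(C)c2)[nH]1` and compound 2 `CCCCc1nc(Cl)c(C2NC(=O)NC(C)=C2C(=O)Nc2ccc(C)cc2)[nH]1` carry no result in an ADME assay on Vero cells (Chlorocebus sabaeus) for cytotoxicity, read by MTT assay, with a stated time of 72 h; a higher number here means a weaker inhibitor, a lower number a stronger inhibitor: compound 1 stands at "not determined" (no result reported) and compound 2 at "not determined" (no result reported). Compound 3 `CCCCc1nc(Cl)c(C2NC(=O)NC(C)=C2C(=O)Nc2ccc([N+](=O)[O-])cc2)[nH]1` gives > 10 ug/mL in this assay, which is a limit of the assay and not a number, as recorded by the limit of > 10 ug/mL in this assay, at which 1 of the 3 values shown sits. Compound 4 `CCCCc1nc(Cl)c(C2NC(=O)NC(C)=C2C(=O)Nc2ccc(Cl)cc2)[nH]1` differs from compound 3 by chloro in place of nitro on an aromatic carbon. Among the compounds with values here, no step between measured compounds exists here, so no measured size guides this change. The expected step that the limit leaves unreadable from compound 3 to compound 4 is none beyond the scatter. Compound 4 is estimated at 15 ug/mL, within 7 ug/mL to 40 ug/mL, and is expected most likely to return a limit again.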

Compound 4, half-maximal inhibitory concentration: 9.4 ug/mL
Compound 4: middle estimate off by 1.6-fold (0.20 log units), on the high side; the measured number falls inside the stated range.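

Compound 4 gives the series its first actual number in this assay, so chloro at this aromatic carbon yields a readable cytotoxicity value. Compound 3 stands at > 10 ug/mL, which is a limit of the assay and not a number. The swap reads as an at least 1.0-fold lower number from compound 3 to compound 4 (0.02 log units; that floor lies within the scatter), so only a floor is known, and no change beyond the scatter is shown: the limit of > 10 ug/mL in this assay, at which 1 of the 4 values shown sits.

Open, on these data alone, is how an amine or a carboxylic acid on the same aromatic carbon would read. Also open, as far as these compounds go, is whether any group here moves the value clearly beyond the scatter.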